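This account rests on a few compounds, and the source may have more. Where it says the series, first, only, none or still open, it means among the compounds named here.

Compound 1 `COc1cc2cc(C#N)ccc2c(OC)c1Oc1cc(NC(C)(C)C)nc(Nc2ccc(C#N)cc2)n1` is the reference point of the set. In an ADME assay on MT4 cells (Homo sapiens) for cytotoxicity, read by MTT assay, with a stated time of 5 days (on this read-out lower numbers stand for higher toxicity in this test and higher numbers for lower toxicity in this test), compound 1 gives > 125000 nM, which is a limit of the assay and not a number. Compound 2 `CCC(C)Nc1cc(Oc2c(OC)cc3cc(C#N)ccc3c2OC)nc(Nc2ccc(C#N)cc2)n1` gives > 125000 nM in this assay, again a limit. Compound 3 `CCCC(C)Nc1cc(Oc2c(OC)cc3cc(C#N)ccc3c2OC)nc(Nc2ccc(C#N)cc2)n1` gives > 125000 nM in this assay, also a limit. The steps among the measured compounds are accordingly unreadable: a step that the two limits leave unreadable from compound 1 to compound 2, a step that the two limits leave unreadable from compound 1 to compound 3 and a step that the two limits leave unreadable from compound 2 to compound 3. Among the measured compounds shown here, the only evidence to point to is the limit of > 125000 nM in this assay, at which 3 of the 3 values shown sit.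

Compound 4 `COc1cc2cc(C#N)ccc2c(OC)c1Oc1cc(NCC2CCOC2)nc(Nc2ccc(C#N)cc2)n1` differs from compound 1 in one place: (oxolan-3-yl)methyl in place of tert-butyl on a nitrogen on an aromatic ring. For the measured compounds named here, none of the measured steps exchanges the tert-butyl for (oxolan-3-yl)methyl, and none has a readable size, so they bear on the step to compound 4 only in that every variation at this nitrogen has so far remained at the limit in this assay. On that basis no readable step in this assay is expected from the change, and a step that the limit leaves unreadable from compound 1 to compound 4 is the estimated step. Compound 4 is expected at about 150000 nM, within 60000 nM to 400000 nM, most likely reported once more as a limit.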

Compound 4, half-maximal cytotoxic concentration: > 125000 nM
Compound 4: only a limit was reported; the forecaster's own chance of this, stated with the estimate: 85%; the middle value lies beyond the limit too.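

Compound 4 joins compound 1, compound 2 and compound 3 as a limit in this assay, so its steps to those three cannot be read: the limit of > 125000 nM in this assay, at which 4 of the 4 values shown sit. The compounds shown leave open the actual half-maximal cytotoxic concentration of each, and whether any change on this nitrogen shifts it.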